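The compounds below may be only part of what the source reports. "The series", "measured", "known", "first", "only" and "open" are said of these compounds alone.

Compound 1 `CCCCCCOP(=O)(O)OCCSC(=S)N1CCCCC1` is the starting point. In an ADME assay on HEK293 cells (Homo sapiens) for inhibition, read by MTT assay, with stated times of 18 h and 4 h (a higher number here means a weaker inhibitor, a lower number a stronger inhibitor), compound 1 gives only a limit of the assay, > 100000 nM. Compound 2 `CCCCCCOP(=O)(O)OCCSC(=S)N1CCN(C)CC1` carries 4-methylpiperazin-1-yl in place of piperidin-1-yl on a thiocarbonyl carbon, and in this assay compound 2 also gives only a limit, > 100000 nM. Compound 3 `CCCCCCOP(=O)(O)OCCSC(=S)N1CCCC1` carries pyrrolidin-1-yl in place of piperidin-1-yl on a thiocarbonyl carbon, and in this assay compound 3 likewise gives only a limit, > 100000 nM. Because all three sit at the limit of > 100000 nM in this assay, at which 3 of the 3 values shown sit, the steps a step that the two limits leave unreadable from compound 1 to compound 2, a step that the two limits leave unreadable from compound 1 to compound 3 and a step that the two limits leave unreadable from compound 2 to compound 3 cannot be read in size or direction. Compound 4 `CCCOP(=O)(O)OCCSC(=S)N1CCCCC1` differs from compound 1 in the chain on the phosphate side: hydrogen in place of propyl on a saturated chain carbon, three bonds along the chain from an oxygen on an unsaturated carbon. Among the measured compounds shown here, none of the measured steps touches that chain, so nothing here shows how shortening it changes the readout; the three variations at the thiocarbonyl carbon all stay at the same limit. The expectation for compound 4 is therefore that it too sits at the limit, an estimated step that the limit leaves unreadable from compound 1 to compound 4. Compound 4 is estimated at 150000 nM, between 50000 nM and 500000 nM.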

Compound 4, half-maximal inhibitory concentration: > 100000 nM
Compound 4: no number, only a limit (the forecaster's own chance of this, stated with the estimate: 85%); the middle value lies beyond the limit too.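

Among the compounds shown here, compound 1 and compound 4 each give only a limit, so no step between them can be read, in size or in direction: the limit of > 100000 nM in this assay, at which 4 of the 4 values shown sit. As far as these compounds go, whether changing the chain or the group on the thiocarbonyl carbon alters inhibition at all in this assay stays open.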